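Trading a Dichlorophenyl for a Bromophenyl on the Chain

The compounds below may be only part of what the source reports. "The series", "measured", "known", "first", "only" and "open" are said of these compounds alone.

Compound 1 `COc1cc(/C=C/C(=O)Nc2cc3c(Nc4ccc(F)c(Cl)c4)ncnc3cc2O[C@H]2CCOC2)cc(OC)c1O` — 30500 nM
Compound 2 `O=C(/C=C/c1cccc(Cl)c1Cl)Nc1cc2c(Nc3ccc(F)c(Cl)c3)ncnc2cc1O[C@H]1CCOC1` — 30100 nM
Compound 3 `COc1cc(/C=C/C(=O)Nc2cc3c(Nc4ccc(F)c(Cl)c4)ncnc3cc2OC)cc(OC)c1` — 38500 nM

Of the compounds shown here, three sharing one core have been tested in a functional assay on MCF7 cells (Homo sapiens) for cytotoxicity, read by MTT assay, with a stated time of 72 h; on this read-out higher numbers stand for weaker inhibition and lower numbers for stronger inhibition. Compound 1 gives 30500 nM, compound 2 gives 30100 nM and compound 3 gives 38500 nM. Compound 2 shows the lowest of the three numbers, but its nearest neighbour, compound 1, sits a hair above it, and even compound 3, the furthest, is within the scatter, so the three cannot be ordered.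

The next compound, compound 4 `O=C(/C=C/c1ccc(Br)cc1)Nc1cc2c(Nc3ccc(F)c(Cl)c3)ncnc2cc1O[C@H]1CCOC1`, has not yet been measured. It differs from compound 2 in one place: 4-bromophenyl in place of 2,3-dichlorophenyl on a double-bonded chain carbon bound to a double-bonded chain carbon

Among the measured compounds shown here, only one measured step bears on a change at this position. Going a 1.0-fold lower number from compound 1 to compound 2 (0.01 log units; within the scatter), a large substitution on the same double-bonded chain carbon left the number unmoved. For the measured compounds named here, compound 3 offers no step of its own, but its value lies with the others. Nothing therefore points to a change beyond the scatter when the 2,3-dichlorophenyl gives way to 4-bromophenyl; the step from compound 2 to compound 4 is expected to be a 1.0-fold lower number from compound 2 to compound 4 (0.00 log units; within the scatter) in this assay. Compound 4 is accordingly estimated at 30000 nM, with a range from 15000 nM to 60000 nM.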

Compound 4, half-maximal inhibitory concentration: 32400 nM
For compound 4 the middle estimate is 1.1-fold (0.03 log units) below the measured one; low and high end bracket the measured number.
By their numbers in this assay, from the lowest: compounds 2, 1, 4 and 3 (each within the scatter of the next).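

With compound 4, a third kind of substituted phenyl now sits on the double-bonded chain carbon, and the number again holds its level in this assay (a 1.1-fold higher number from compound 2 to compound 4 (0.03 log units; within the scatter)). Among the compounds shown here, the step that spans the two more distant groups, 4-hydroxy-3,5-dimethoxyphenyl and 4-bromophenyl, stays within the scatter as well (a 1.1-fold higher number from compound 1 to compound 4 (0.03 log units; within the scatter)), so this position now tolerates a single bromine, two chlorines, or a hydroxy group with two methoxy groups on the ring without a readable change, where the earlier compounds offered only one such swap. No measurement at hand explains why these three rings give matching numbers.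

From the compounds shown here alone, all three compounds with the shared tetrahydrofuranyl-free comparison aside carry a phenyl ring here, so it remains open whether a ring bearing an amine or a carboxylic acid, or a plain alkyl chain in place of the ring, would shift the number at all. Every value shown also lies in one narrow band, which leaves open whether any change at this position can reach beyond the scatter in this cell assay.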